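From cyclopropylmethoxy to bromo: an expected small step

The source may report more compounds than this note shows. Statements on the series, on what has been measured and on what is new or still open speak of the compounds shown alone.

Values in a functional assay on K562 cells (Homo sapiens) for antiproliferative activity, read by MTT assay, with a stated time of 48 h; a lower number here means a stronger inhibitor of growth, a higher number a weaker inhibitor of growth:
Compound 1 `COc1ccccc1OCCNc1ccc(=O)n(Cc2ccc(OC)c(OC3CCCC3)c2)n1`: 28000 nM
Compound 2 `COc1ccc(Cn2ncc(NCCOc3ccccc3OC)c(Cl)c2=O)cc1OC`: > 100000 nM, a limit of the assay
Compound 3 `COc1ccccc1OCCNc1ccc(=O)n(Cc2ccc(OC)c(OCC3CC3)c2)n1`: 16600 nM

Among the compounds with values here, compound 3 stands within the scatter of compound 1, the only other compound with a number. Compound 2 gives only a limit. Compound 4 `COc1ccc(Cn2nc(NCCOc3ccccc3OC)ccc2=O)cc1Br` differs from compound 3 as follows: bromo in place of cyclopropylmethoxy on an aromatic carbon. This puts bromo in place of cyclopropylmethoxy, ortho to a methoxy group. Within the data shown here, the one measured step bearing on this is a 1.7-fold lower number from compound 1 to compound 3 (0.23 log units; within the scatter), which exchanged only the group on that oxygen and so offers limited guidance. No step beyond the scatter is expected in this assay, and the estimate is a 1.5-fold higher number from compound 3 to compound 4 (0.18 log units; within the scatter). The expected value for compound 4 is 25000 nM, with an estimated range of 9000 nM to 80000 nM.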

Compound 4, concentration for 50% growth inhibition: > 100000 nM
Compound 4 was reported as a limit; the forecaster's own chance of this, stated with the estimate: 15%; middle value at least 4.0-fold (0.60 log units) from the limit.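

In this assay, this position, ortho to a methoxy group, proved sensitive to the change. The earlier exchange on the oxygen stayed within the scatter, whereas bromo in place of the alkoxy group gave an at least 6.0-fold higher number from compound 3 to compound 4 (0.77 log units; beyond the scatter) and also an at least 3.5-fold higher number from compound 1 to compound 4 (0.55 log units; beyond the scatter). Compound 4 gives only a limit, so both steps are lower bounds, and their full size cannot be read: the limit of > 100000 nM in this assay, at which 2 of the 4 values shown sit.

Still open, going by these compounds, is whether a hydroxyl or an amine at this position would keep the growth inhibition of compound 3. Also open, on these data alone, is whether an ethoxy group would do so.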